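The source may hold more compounds than are shown below. What is called first, only, known or untested is meant among the compounds shown, and "the series" means these compounds.

Three compounds have been measured in a functional assay on HT-29 cells (Homo sapiens) for cytotoxicity, read by MTT assay, with a stated time of 72 h; on this read-out lower numbers stand for stronger inhibition and higher numbers for weaker inhibition:

Compound 1, `CN(C)CCNc1nc(-c2ccc(NC(=O)Nc3ccccc3Cl)cc2)nc2ccsc12`, gives 310 nM.
Compound 2, `CCN(CC)CCCNc1nc(-c2ccc(NC(=O)Nc3ccc(F)cc3)cc2)nc2ccsc12`, gives 340 nM.
Compound 3, `CCN(CC)CCCNc1nc(-c2ccc(NC(=O)Nc3ccccc3F)cc2)nc2ccsc12`, gives 550 nM.

Compound 3 thus has the highest of the three numbers, but its gaps to the other two are small: to compound 2 it is within the scatter, and to compound 1 it is within the scatter as well, so none of the three can be set apart from the others.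

Compound 4, `CCN(CC)CCCNc1nc(-c2ccc(NC(=O)Nc3ccccc3Cl)cc2)nc2ccsc12`, has not yet been measured. It differs from compound 3 in one place: chloro in place of fluoro on an aromatic carbon.

Among the compounds with values here, only one measured step bears on this part of the molecule, a 1.6-fold higher number from compound 2 to compound 3 (0.21 log units; within the scatter), which moves the halogen around the ring rather than exchanging one halogen for another and stays within the scatter. Compound 1 also carries the 2-chlorophenyl group, but it differs from compound 3 in the amine chain too, so its value and that of compound 3 show only that the two lie within the scatter of each other. Within the data shown here, no measured step isolates the exchange of fluoro for chloro, and nothing seen so far suggests a change beyond the scatter; the expected step is therefore a 1.3-fold lower number from compound 3 to compound 4 (0.12 log units; within the scatter).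

Compound 4 is expected to give about 420 nM in this assay, with a likely range from 200 nM to 900 nM.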

Compound 4, half-maximal inhibitory concentration: 340 nM
For compound 4 the middle estimate is 1.2-fold (0.09 log units) above the measured one, and the stated range covers the measured number.
By their numbers in this assay, from the lowest: compounds 1, 2, 4 and 3 (each within the scatter of the next).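

In this assay the exchange of fluoro for chloro on this aromatic carbon, ortho to a large group, can now be read on its own: it gives a 1.6-fold lower number from compound 3 to compound 4 (0.21 log units; within the scatter), so among these compounds this position carries either halogen without a step beyond the scatter. Within the data shown here, compound 4 also gives the first step that reads the amine chain alone, since with the 2-chlorophenyl group held, (diethylamino)methyl in place of dimethylamino gives a 1.1-fold higher number from compound 1 to compound 4 (0.04 log units; within the scatter), while 2-chlorophenyl in place of 4-fluorophenyl gives no change at the digits printed from compound 2 to compound 4 (within the scatter), so neither the chain nor the halogen change separates these compounds. Nothing on hand offers an explanation for any of these steps.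

Still open is whether a bromo, methyl or methoxy group on this carbon, or a plain phenyl with no substituent at all, would stay within the scatter of these compounds. From the compounds shown here alone, it is equally open whether a morpholine or piperidine at the end of the chain, in place of the dimethylamino or diethylamino group, would move the number beyond the scatter.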